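From butyl to propyl on the shared core

The source may hold more compounds than are shown below. What is called first, only, known or untested is meant among the compounds shown, and "the series" means these compounds.

In a functional assay on A549 cells (Homo sapiens) for antiproliferative activity, read by MTT assay, with a stated time of 48 h (a higher number here means a weaker inhibitor of growth, a lower number a stronger inhibitor of growth), compound 1 `CCCCCN(Cc1ccc(C(=O)NO)cc1)c1ncc(-c2ccc(C)cc2)s1` gives 9140 nM, compound 2 `Cc1ccc(OCCCN(Cc2ccc(C(=O)NO)cc2)c2ncc(-c3ccc(C)cc3)s2)cc1` gives 32500 nM and compound 3 `CCCCN(Cc1ccc(C(=O)NO)cc1)c1ncc(-c2ccc(C)cc2)s1` gives 4780 nM. Compound 3 is separated from only one of the other two values: a 1.9-fold lower number from compound 1 to compound 3 (0.28 log units; within the scatter), against a 6.8-fold lower number from compound 2 to compound 3 (0.83 log units; beyond the scatter).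

Compound 4 `CCCN(Cc1ccc(C(=O)NO)cc1)c1ncc(-c2ccc(C)cc2)s1` shortens the butyl chain of compound 3 to propyl, with hydrogen in place of methyl on a saturated chain carbon, three bonds along the chain from a nitrogen on an aromatic ring.

Within the data shown here, the closest precedent is the same exchange of methyl for hydrogen four bonds along the chain, in compound 3 with a 1.9-fold lower number from compound 1 to compound 3 (0.28 log units; within the scatter). The larger change to compound 2, with a 3.6-fold higher number from compound 1 to compound 2 (0.55 log units; beyond the scatter), brings in 4-methylphenoxy and offers little guidance for so small an edit. On this single precedent, no step beyond the scatter is expected, and the estimate is a 1.3-fold lower number from compound 3 to compound 4 (0.12 log units; within the scatter). For compound 4 the estimated value is 3600 nM, with an expected range of 1600 nM to 8000 nM.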

Compound 4, concentration for 50% growth inhibition: 3310 nM
Estimate against measurement, compound 4: 1.1-fold (0.04 log units) above; low and high end bracket the measured number.
By their numbers in this assay, from the lowest: compounds 4, 3 and 1 (each within the scatter of the next, the first and the last beyond it); then compound 2.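

Going from butyl to propyl at this position produces no step that can be told from the scatter in this assay (a 1.4-fold lower number from compound 3 to compound 4 (0.16 log units; within the scatter)), so compound 3 and compound 4 cannot be ranked. Compound 4 does separate from the longer chain of compound 1 (a 2.8-fold lower number from compound 1 to compound 4 (0.44 log units; beyond the scatter)), although compound 3 separates from neither, and the step from the 4-methylphenoxy chain is the widest at this position (a 9.8-fold lower number from compound 2 to compound 4 (0.99 log units; beyond the scatter)). Nothing available bears on why these numbers move with the chain.

As far as these compounds go, whether the numbers keep falling or turn back with an ethyl or methyl group on the nitrogen remains open. So does the effect of a propyl chain ending in an amine or a carboxylic acid, set against the 4-methylphenoxy end of compound 2.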